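This account rests on a few compounds, and the source may have more. Where it says the series, first, only, none or still open, it means among the compounds named here.

Notes on the series

The shared core is held constant across the set; the variation lies in the groups carried on it. Compound 1 `CC(=O)Nc1cc(C(=O)O)cc(-n2c(C)ccc2-c2cc(Br)ccc2OCc2ccc(F)cc2F)c1` gives 0.398 nM in an assay on CHO cells for displacement of a labelled ligand from prostaglandin E2 receptor EP1 subtype (Homo sapiens); on this read-out higher numbers stand for weaker inhibition and lower numbers for stronger inhibition. Compound 2 `Cc1ccc(-c2cc(Cl)ccc2OCc2ccc(F)cc2F)n1-c1cc(C(=O)O)ccc1F` gives 6.31 nM in this assay, and compound 3 `CC(=O)Nc1cc(C(=O)O)cc(-n2c(C)ccc2-c2cc(Cl)ccc2OCc2ccc(F)cc2)c1` gives 2.51 nM. Compound 1 thus stands at the lowest number of the three measured, with compound 3 nearest and compound 2 furthest, both gaps beyond the scatter, so compound 1 is the strongest inhibitor among those measured. Among the measured compounds shown here, compound 2 and compound 3 differ from compound 1 in more than one place each, so no single step between measured compounds can be read from these values.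

Compound 4 `Cc1ccc(-c2cc(Br)ccc2OCc2ccc(F)cc2F)n1-c1cc(N)cc(C(=O)O)c1` has not yet been measured. It differs from compound 1 in one place: hydrogen in place of acetyl on a nitrogen on an aromatic ring. For the measured compounds named here, no measured pair in the set shows what this change does, so the expectation rests on the neighbourhood of compound 1 alone. Compound 4 is expected to remain close to compound 1, with a small step towards a higher number, a 2.0-fold higher number from compound 1 to compound 4 (0.30 log units; within the scatter), which may well lie within the scatter. Compound 4 is therefore estimated at 0.8 nM in this assay, with a range from 0.2 nM to 4 nM.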

Compound 4, half-maximal inhibitory concentration: 0.501 nM
The estimate for compound 4 lay 1.6-fold (0.20 log units) above the measured number; the measured number falls inside the stated range.
By their numbers in this assay, from the lowest: compounds 1 and 4 (each within the scatter of the next); then compound 3; then compound 2.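

Among the compounds shown here, the first readable step at this position, the nitrogen on the aromatic ring, is acetamido to amino: in this assay it gives a 1.3-fold higher number from compound 1 to compound 4 (0.10 log units; within the scatter). The acetyl, with its 3 heavy atoms, its double bond outside the aromatic rings and its hydrogen-bond acceptor, can therefore be replaced by hydrogen on this background without a shift that the read-out can separate from the scatter, so the low number of compound 1 does not depend on that acetyl. No measurement at hand accounts for why the acetamido and amino forms read alike here.

This single step rests on one background, and steps linking compound 2 or compound 3 to compound 1 or compound 4 cannot be read, as each pair differs in more than one place. Going by these compounds, whether a methyl, a longer acyl chain such as butanoyl, or a methanesulfonyl on the same nitrogen would also read alike remains open, as does whether the amino form would hold on a background carrying chlorine in place of bromine.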